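This account rests on a few compounds, and the source may have more. Where it says the series, first, only, none or still open, it means among the compounds named here.

Compound 2 `C=C1CC/C=C(\C)CC[C@@H]2[C@H](CC/C=C(\C)CO)C(=O)OC[C@@H]12` and compound 1 `C=C1CC[C@@H]2O[C@@]2(C)CC[C@@H]2[C@H](CC/C=C(\C)C(=O)OC)C(=O)OC[C@@H]12` have a shared core but differ in several places. In a functional assay on K562 cells (Homo sapiens) for cytotoxicity (a lower number here means that less compound is tolerated, a higher number that more compound is tolerated), compound 1 gives 3.9 ug/mL, while compound 2 gives 1.2 ug/mL, the lower of the two numbers, a gap beyond the usual scatter. Compound 3 `C=C1CC/C=C(\C)CC[C@@H]2[C@H](CC/C=C/CO)C(=O)OC[C@@H]12` differs from compound 2 in a single place: 3-hydroxyprop-1-en-1-yl in place of 2-(hydroxymethyl)prop-1-en-1-yl on a saturated chain carbon, two bonds along the chain from a saturated ring carbon. For the measured compounds named here, no measured pair isolates this change, so the step is expected to be small, within the scatter, and the estimated 1.3-fold higher number from compound 2 to compound 3 (0.10 log units; within the scatter) reflects that. Compound 3 is therefore expected to give 1.5 ug/mL, in a likely range from 0.6 ug/mL to 4 ug/mL.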

Compound 3, concentration lethal to 50% of the cells: 1.5 ug/mL
Beside the measured number, compound 3's estimate shows no gap at the digits printed; the measured number falls inside the stated range.
By their numbers in this assay, from the lowest: compounds 2 and 3 (each within the scatter of the next); then compound 1.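

In this assay, 3-hydroxyprop-1-en-1-yl in place of 2-(hydroxymethyl)prop-1-en-1-yl gives a 1.3-fold higher number from compound 2 to compound 3 (0.10 log units; within the scatter), so this single change leaves the number within the scatter. For the compounds shown here, this is the first comparison that isolates one place, here on a saturated chain carbon, two bonds along the chain from a saturated ring carbon. No supporting data bear on why the number holds. On these data alone, how an amine or a carboxylic acid at the end of this chain would read remains open. So does how much of the gap to compound 1 belongs to this position, since compound 1 differs from compound 2 in several places.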